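A few compounds are considered here, and "the series" means these few. Any claim that something is new, unique, unknown or untested is made for them only; others in the source may bear on it.

Working notes on a small stilbene-type series tested in a functional assay on the whole organism with Mus musculus as the target, in the maximal electroshock model, at a dose of 50 mg/kg by the oral route; a lower number here means less inhibition, a higher number more inhibition at the dose given (going by the name of the read-out).

Of the compounds shown here, three have numbers so far. Compound 1 `COc1ccccc1/C=C/c1ccccc1OCCCCN(C)C` gives 0% in this assay. Compound 3 `CN(C)CCCCOc1cccc(/C=C/c2ccccc2)c1` likewise gives 0%. Compound 2 `C(=C/c1ccccc1OCCCCN1CCCC1)\c1ccccc1` gives 42.9% and stands highest of the three, the gap to both compound 1 and compound 3 lying beyond the scatter. Compound 1 and compound 3 cannot be told apart on their values.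

Compound 4 `OCC1CCCN(CCCCOc2ccccc2/C=C/c2ccccc2)C1` has not yet been measured in this assay. It differs from compound 2 in one place: 3-(hydroxymethyl)piperidin-1-yl in place of pyrrolidin-1-yl on a saturated chain carbon, four bonds along the chain from an oxygen on an aromatic ring.

For the measured compounds named here, no pair of measured compounds differs in exactly this way, so the size of this step has no precedent. Compound 4 is expected to stay in the region of compound 2, whose value in this assay is 42.9%, with a step of a number 4.9 percentage points lower from compound 2 to compound 4 (within the scatter) that is estimated to lie within the scatter. On that basis compound 4 is estimated at 38% in this assay, between 5% and 70%.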

Compound 4, a percentage reported as inhibition, in the whole organism at one dose (the size of the read-out at that dose, not a potency): 12.5%
For compound 4 the middle estimate is 25.5 percentage points above the measured one; the range from low to high includes it.
By their numbers in this assay, from the lowest: compounds 1 and 3 (each within the scatter of the next); then compound 4; then compound 2.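

The step at this position is large: with 3-(hydroxymethyl)piperidin-1-yl in place of pyrrolidin-1-yl on a saturated chain carbon, four bonds along the chain from an oxygen on an aromatic ring, this assay shows a number 30.4 percentage points lower from compound 2 to compound 4 (beyond the scatter), so the group here is not interchangeable in this series. For the compounds shown here, the change alters ring size and adds a hydroxymethyl at once, and compound 4 still gives 12.5%, so the single step cannot be divided between these two differences. Nothing available bears on what lies behind this step.

The compounds shown leave open whether ring size or the hydroxymethyl accounts for the step, a question that plain piperidin-1-yl or 3-(hydroxymethyl)pyrrolidin-1-yl at this position would address. From the compounds shown here alone, how morpholin-4-yl would behave here also stays open.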